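This account rests on a few compounds, and the source may have more. Where it says the series, first, only, none or still open, it means among the compounds named here.

Working notes on the series.

Compound 1 `O=C(Nc1ccc(Oc2ccnc3[nH]ccc23)cc1)c1cn(-c2ccc(F)c(Cl)c2)c2ccccc2c1=O` gives 4810 nM in a functional assay on A549 cells (Homo sapiens) for inhibition, read by MTT assay, with a stated time of 72 h; on this read-out higher numbers stand for weaker inhibition and lower numbers for stronger inhibition. Compound 2 `COc1ccc(-n2cc(C(=O)Nc3ccc(Oc4ccnc5[nH]ccc45)cc3)c(=O)c3ccccc32)cc1` differs from compound 1 by 4-methoxyphenyl in place of 3-chloro-4-fluorophenyl on an aromatic nitrogen, and in this assay compound 2 gives 4980 nM; the step of a 1.0-fold higher number from compound 1 to compound 2 (0.02 log units; within the scatter). Compound 3 `O=C(Nc1ccc(Oc2ccnc3[nH]ccc23)c(F)c1)c1cn(-c2ccc(F)c(Cl)c2)c2ccccc2c1=O` has a core that differs from that of compound 1 by fluoro in place of hydrogen on an aromatic carbon, and in this assay compound 3 gives 2150 nM; the step of a 2.2-fold lower number from compound 1 to compound 3 (0.35 log units; beyond the scatter). Among the three measured compounds compound 3 has the lowest number, and its steps to compound 1 and to compound 2 are both beyond the scatter.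

Compound 4 `COc1ccc(-n2cc(C(=O)Nc3ccc(Oc4ccnc5[nH]ccc45)c(F)c3)c(=O)c3ccccc32)cc1` has not been measured in this assay. It differs from compound 3 by 4-methoxyphenyl in place of 3-chloro-4-fluorophenyl on an aromatic nitrogen. This is the change already made from compound 1 to compound 2, and the place around it is described in the same words for both pairs, so it is the same change made on the core of compound 3 rather than on the core of compound 1. Among the compounds with values here, the only precedent for this change is the step from compound 1 to compound 2, which is within the scatter.

The step expected from compound 3 to compound 4 in this assay is a 1.0-fold higher number from compound 3 to compound 4 (0.01 log units; within the scatter), essentially flat, because the earlier step of a 1.0-fold higher number from compound 1 to compound 2 (0.02 log units; within the scatter) is within the scatter. Compound 4 is therefore expected to give about 2200 nM in this assay. Within the data shown here, the expected range for compound 4 runs from 1100 nM to 4500 nM, wider than the single precedent alone would suggest since only one example of the change exists.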

Compound 4, half-maximal inhibitory concentration: 4150 nM
Estimate against measurement, compound 4: 1.9-fold (0.28 log units) below, within the range that was stated.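

In this assay, 4-methoxyphenyl in place of 3-chloro-4-fluorophenyl on the fluoro-bearing core gives a 1.9-fold higher number from compound 3 to compound 4 (0.29 log units; within the scatter), and fluoro in place of hydrogen on an aromatic carbon, with 4-methoxyphenyl on the aromatic nitrogen, gives a 1.2-fold lower number from compound 2 to compound 4 (0.08 log units; within the scatter). Set beside its earlier step, the exchange of the two aryl groups shows no difference between the cores that can be told from the scatter: the same change on two cores in this assay, a 1.0-fold higher number (0.02 log units; within the scatter) from compound 1 to compound 2 and a 1.9-fold higher number (0.29 log units; within the scatter) from compound 3 to compound 4, 1.9-fold (0.27 log units) apart, within the scatter of two such steps. The fluoro change shows no such difference either, yet its step lies beyond the scatter on one core and within it on the other, and two pairs per change do not show that either change carries the same way to further cores: the same change on two cores in this assay, a 2.2-fold lower number (0.35 log units; beyond the scatter) from compound 1 to compound 3 and a 1.2-fold lower number (0.08 log units; within the scatter) from compound 2 to compound 4, 1.9-fold (0.27 log units) apart, within the scatter of two such steps.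

The compounds shown leave open how the same steps would read with other groups on the aromatic nitrogen, such as an unsubstituted phenyl, a short alkyl chain, or a phenyl bearing an amine or a carboxylic acid. Also open, from the compounds shown here alone, is what chloro or methyl in place of the fluoro would give in this assay on either core.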